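Chloro on the phenyl, with both parents near the ceiling

The source may report more compounds than this note shows. Statements on the series, on what has been measured and on what is new or still open speak of the compounds shown alone.

Compound 1 `O=C(Nc1ccccc1)Nc1ccc(Oc2ncnc3c2cnn3-c2ccccc2)cc1` gives > 100000 nM in a functional assay on MCF7 cells (Homo sapiens) for cytotoxicity, read by sulforhodamine B assay, with a stated time of 72 h; a lower number here means a stronger inhibitor, a higher number a weaker inhibitor; that figure is a limit of the assay and not a number.
Compound 2 `O=C(Nc1ccccc1)Nc1ccc(Oc2ncnc3c2cnn3-c2ccc(Cl)cc2)cc1` gives 82500 nM in this assay.
Compound 3 `Clc1ccc2nc(Nc3ncnc4c3cnn4-c3ccccc3)sc2c1` gives > 100000 nM in this assay; that figure is a limit of the assay and not a number.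

Compound 1 and compound 2 share one core and differ only by chloro in place of hydrogen on an aromatic carbon. The step in this assay is an at least 1.2-fold lower number from compound 1 to compound 2 (0.08 log units; that floor lies within the scatter), and its floor is set because compound 1 sits at the limit of > 100000 nM in this assay, at which 2 of the 3 values shown sit.

Compound 4 `Clc1ccc(-n2ncc3c(Nc4nc5ccc(Cl)cc5s4)ncnc32)cc1` is not yet measured. It differs from compound 3 by chloro in place of hydrogen on an aromatic carbon, the same change as that from compound 1 to compound 2, made at a place described in the same words. How the core of compound 3 differs from the core of compound 1 is not broken down here.

Compound 3 sits at the limit of the assay, so only a floor for any gain is known on that side. Compound 4 is expected to move by about an at least 1.1-fold lower number from compound 3 to compound 4 (0.07 log units; that floor lies within the scatter) in this assay, resting on the step of an at least 1.2-fold lower number from compound 1 to compound 2 (0.08 log units; that floor lies within the scatter) seen on the other core. For compound 4 the expected value in this assay is therefore 85000 nM, within 35000 nM to 300000 nM, with a real chance that the assay again reports only a limit.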

Compound 4, half-maximal inhibitory concentration: 85600 nM
For compound 4 the middle estimate is 1.0-fold (0.00 log units) below the measured one, within the range that was stated.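

In this assay, the chloro change on the core of compound 3 gives an at least 1.1-fold lower number from compound 3 to compound 4 (0.06 log units; that floor lies within the scatter), so the change has now been followed on two cores, and on both it ends in a readable value rather than a limit. Set side by side, the two steps can be neither called equal nor told apart: the same change on two cores in this assay, an at least 1.2-fold lower number (0.08 log units; that floor lies within the scatter) from compound 1 to compound 2 and an at least 1.1-fold lower number (0.06 log units; that floor lies within the scatter) from compound 3 to compound 4; the limit leaves it open whether they differ. Among the compounds shown here, the result therefore shows only that compound 2 and compound 4, the two members carrying 4-chlorophenyl, both give readable values, and it does not show how large the gain from phenyl to 4-chlorophenyl really is on either core, since the phenyl parents on both cores stand at the ceiling: the limit of > 100000 nM in this assay, at which 2 of the 4 values shown sit.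

The compounds shown leave open whether another group in the same place on the phenyl, such as fluoro, methoxy or an amine, would bring a value well clear of the limit in this assay. They also leave open whether the change from phenyl to 4-chlorophenyl would hold on a third core, and whether a carboxylic acid or a longer chain at that place would behave as chloro does.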